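Swapping an amino group for chloro on a fused two-ring core

The compounds below may be only part of what the source reports. "The series", "measured", "known", "first", "only" and "open" are said of these compounds alone.

Of the compounds shown here, three built on one shared core have been tested in a functional assay on CEM-SS cells (Homo sapiens) for cytotoxicity; a higher number here means a weaker inhibitor, a lower number a stronger inhibitor. Compound 1, `Cc1ccc(Cn2c(N)nc3cc(Cl)c(Cl)cc32)cc1`, gives 40000 nM. Compound 2, `Nc1nc2cc(Cl)c(Cl)cc2n1Cc1ccccc1Cl`, carries a different side group on the core; how its core differs from that of compound 1 is not broken down here. In this assay compound 2 gives 36000 nM, which lies within the scatter of the value of compound 1. Compound 3, `Cc1ccc(Cn2c(Cl)nc3cc(Cl)c(Cl)cc32)cc1`, differs from compound 1 by chloro in place of amino on an aromatic carbon. For compound 3 the result in this assay is only a limit of the assay, > 100000 nM, and not a number. The step of an at least 2.5-fold higher number from compound 1 to compound 3 (0.39 log units; beyond the scatter) is therefore known only as a lower bound because the limit of > 100000 nM in this assay, at which 1 of the 3 values shown sits, is what was reported for compound 3.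

Compound 4, `Clc1cc2nc(Cl)n(Cc3ccccc3Cl)c2cc1Cl`, is not yet measured. It differs from compound 2 by chloro in place of amino on an aromatic carbon, the same change that turns compound 1 into compound 3. Starting from compound 2 at 36000 nM, a step of the size seen from compound 1 to compound 3 is expected, so compound 4 is estimated to reach a higher number in this assay, with a 2.8-fold higher number from compound 2 to compound 4 (0.44 log units; beyond the scatter). The estimate for compound 4 is 100000 nM.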

Compound 4, half-maximal inhibitory concentration: 70000 nM
Compound 4: the middle estimate sits 1.4-fold (0.15 log units) above what was measured, within the range that was stated.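

In this assay, chloro in place of amino on the core of compound 2 gives a 1.9-fold higher number from compound 2 to compound 4 (0.29 log units; within the scatter), so this case alone does not show a real shift in the number. Set beside the earlier case, it neither shows that the change carries over from one core to the other with the same size nor shows that the two cores respond differently: the same change on two cores in this assay, an at least 2.5-fold higher number (0.39 log units; beyond the scatter) from compound 1 to compound 3 and a 1.9-fold higher number (0.29 log units; within the scatter) from compound 2 to compound 4; the limit leaves it open whether they differ Compound 3 is reported only as a limit of the assay, > 100000 nM, and not as a number.

The compounds shown place only amino or chloro on the aromatic carbon between the two ring nitrogen atoms, so it stays open how a methyl, a hydroxyl or a longer amine chain there would read in this assay. From the compounds shown here alone, it also stays open whether the change would behave the same way on a core whose side group carries a carboxylic acid or an amine.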